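Adding a second methoxy to compound 2

The source may report more compounds than this note shows. Statements on the series, on what has been measured and on what is new or still open speak of the compounds shown alone.

In an ADME assay on CHO cells (Cricetulus griseus) for cytotoxicity, read by LDH release (on this read-out higher numbers stand for weaker inhibition and lower numbers for stronger inhibition), compound 2 `COc1cccc(CNC(=O)C(C)Oc2ccc(Cl)cc2Cl)c1` gives > 100000 nM, which is a limit and not a number. Compound 1 `COc1ccc(CNC(=O)C(C)Oc2ccc(Cl)cc2Cl)cc1`, which carries its methoxy elsewhere on the same ring, reads 71000 nM in this assay. Among the measured compounds shown here, no measured step isolates the next change. Compound 3 `COc1ccc(CNC(=O)C(C)Oc2ccc(Cl)cc2Cl)cc1OC` differs from compound 2 by methoxy in place of hydrogen on an aromatic carbon. Compound 3 thus holds the methoxy groups of both neighbours, and compound 1 at 71000 nM suggests that a number close to the top of the range is expected. The expected change is small, an at least 1.1-fold lower number from compound 2 to compound 3 (0.07 log units; that floor lies within the scatter), and possibly no larger than the scatter, with any movement toward lower numbers. A reading at the limit is also possible. For compound 3 the estimated value is 85000 nM, with an expected range of 40000 nM to 150000 nM.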

Compound 3, half-maximal inhibitory concentration: 36000 nM
The estimate for compound 3 lay 2.4-fold (0.37 log units) above the measured number; measured number outside the range, below it.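

In this assay, among the compounds shown here, methoxy in place of hydrogen on an aromatic carbon, ortho to a methoxy group and para to a large group, gives an at least 2.7-fold lower number from compound 2 to compound 3 (0.44 log units; beyond the scatter), the first step that can be read beyond the scatter. Reached by the other single change, the same product shows a 2.0-fold lower number from compound 1 to compound 3 (0.29 log units; within the scatter), so the two routes to the pair of methoxy groups do not read alike. The value for compound 2 is a limit and not a number, so the first step has a floor and no fixed size: the limit of > 100000 nM in this assay, at which 1 of the 3 values shown sits.

Still open, on these data alone, is how large that step really is. Also open, as far as these compounds go, is whether it belongs to methoxy as such, which an ethoxy or a hydroxyl on the same aromatic carbon would test.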